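Fluorophenyl Ketone Analogue Within a Shared Chalcone Series

The source may report more compounds than this note shows. Statements on the series, on what has been measured and on what is new or still open speak of the compounds shown alone.

The series shares one core, carrying an ester-bearing isoxazole and an amide-linked enone. Compound 1 `COC(=O)c1cc(-c2cccc(NC(=O)c3ccc(/C=C/C(=O)c4cccc(OC)c4)cc3)c2)on1` has a 3-methoxyphenyl on the carbonyl carbon; in an ADME assay on Vero cells (Chlorocebus sabaeus) for cytotoxicity, read by MTT assay, with a stated time of 72 h (on this read-out higher numbers stand for lower toxicity in this test and lower numbers for higher toxicity in this test), compound 1 gives only a limit of the assay, > 100 ug/mL. Compound 2 `COC(=O)c1cc(-c2cccc(NC(=O)c3ccc(/C=C/C(=O)c4ccc(C)c([N+](=O)[O-])c4)cc3)c2)on1` carries a 4-methyl-3-nitrophenyl at the same place, and in this assay compound 2 also gives only a limit, > 80 ug/mL. The step from compound 1 to compound 2 in this assay, a step that the two limits leave unreadable from compound 1 to compound 2, is therefore not readable in size. Compound 3 `COC(=O)c1cc(-c2cccc(NC(=O)c3ccc(/C=C/C(=O)c4ccccc4O)cc3)c2)on1`, with a 2-hydroxyphenyl on the carbonyl carbon, has no number in this assay: compound 3 is recorded as "not determined" (no result reported). Compound 4 `COC(=O)c1cc(-c2cccc(NC(=O)c3ccc(/C=C/C(=O)c4ccc(F)cc4)cc3)c2)on1` differs from compound 3 by 4-fluorophenyl in place of 2-hydroxyphenyl on a carbonyl carbon. For the measured compounds named here, no measured step bears directly on this change; the only evidence is the limit of > 100 ug/mL in this assay, at which 1 of the 3 values shown sits, and (the limit of > 80 ug/mL in this assay, at which 1 of the 3 values shown sits), both limits. On that basis compound 4 is expected to sit near the limit as well, estimated at 100 ug/mL, between 50 ug/mL and 200 ug/mL.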

Compound 4, half-maximal cytotoxic concentration: > 20 ug/mL
Compound 4: no number, only a limit; the forecaster's own chance of this, stated with the estimate: 80%; the middle value does not contradict the limit.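

Compound 4 gives only a limit in this assay, as do compound 1 and compound 2, so the steps from compound 1 and from compound 2 to compound 4 cannot be read. The compounds shown leave open whether 4-fluorophenyl, 3-methoxyphenyl and 4-methyl-3-nitrophenyl on the carbonyl carbon differ at all in cytotoxicity.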